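A few compounds are considered here, and "the series" means these few. Any claim that something is new, unique, unknown or untested is made for them only; others in the source may bear on it.

Measured compounds in a functional assay on HepG2 cells (Homo sapiens) for cytotoxicity, read by MTT assay, with a stated time of 72 h; on this read-out higher numbers stand for weaker inhibition and lower numbers for stronger inhibition:
compound 1 `COc1c(OCCCCN2CCN(C)CC2)cc(O)c2c(=O)cc(-c3ccc(C)cc3)oc12`: 1000 nM
compound 2 `COc1c(OCCCCN2CCN(C)CC2)cc(O)c2c(=O)cc(-c3ccc(F)cc3)oc12`: 2810 nM
compound 3 `COc1c(OCCCCN2CCN(C)CC2)cc(O)c2c(=O)cc(-c3ccc(Br)cc3)oc12`: 2320 nM

Compound 1 gives the lowest number of the three in this assay; compound 3 lies nearest to it and compound 2 furthest, and both of those steps are beyond the scatter. Compound 4 `COc1c(OCCCCN2CCN(C)CC2)cc(O)c2c(=O)cc(-c3ccc(F)cc3Br)oc12` has not yet been measured. It differs from compound 1 in one place: 2-bromo-4-fluorophenyl in place of 4-methylphenyl on an aromatic carbon. Going by the values given here, two measured steps bear on this change, since each swaps the methyl of compound 1 for one of the two halogens that compound 4 carries together on the same ring: a 2.8-fold higher number from compound 1 to compound 2 (0.45 log units; beyond the scatter) and a 2.3-fold higher number from compound 1 to compound 3 (0.37 log units; beyond the scatter). The two halogen compounds themselves sit within the scatter of each other, a 1.2-fold lower number from compound 2 to compound 3 (0.08 log units; within the scatter). Among the compounds with values here, both single replacements moved the number upward by a modest amount, and a step of similar size in the same direction is expected for the doubly substituted ring, although no measured pair shows what a second halogen on the same ring adds. Compound 4 is estimated at 2500 nM in this assay, with a range of 1000 nM to 6300 nM, which corresponds to an expected step of a 2.5-fold higher number from compound 1 to compound 4 (0.40 log units; beyond the scatter).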

Compound 4, half-maximal inhibitory concentration: 2130 nM
Estimate against measurement, compound 4: 1.2-fold (0.07 log units) above, within the range that was stated.
By their numbers in this assay, from the lowest: compound 1; then compounds 4, 3 and 2 (each within the scatter of the next).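

In this assay the 2-bromo-4-fluorophenyl ring in place of 4-methylphenyl gives a 2.1-fold higher number from compound 1 to compound 4 (0.33 log units; beyond the scatter) and so stays with the single-halogen rings, apart from compound 1. Bromo in place of hydrogen on the fluorinated ring gives a 1.3-fold lower number from compound 2 to compound 4 (0.12 log units; within the scatter) and the change from 4-bromophenyl gives a 1.1-fold lower number from compound 3 to compound 4 (0.04 log units; within the scatter) so that both steps lie within the scatter, and a second halogen on this ring adds no readable change in this assay. No measurement at hand accounts for the difference between the methyl-bearing ring and the halogen-bearing rings.

Open, on these data alone, is whether a methoxy, an amine or a carboxylic acid on this ring would give a number closer to compound 1 or further from it. Also open, as far as these compounds go, is whether the methyl of compound 1 would give the same step when joined by a second group on the ring.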